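Acid in Place of Alcohol on the Side Chain

A few compounds are considered here, and "the series" means these few. Any claim that something is new, unique, unknown or untested is made for them only; others in the source may bear on it.

Compound 1, `Cn1c(Cc2nn(C)c(=O)c3ccccc23)nnc1SCCCCCCCC(=O)Nc1ccc(Cl)cc1Cl`, gives 3900 nM.
Compound 2, `Cn1c(Cc2nn(CCCO[Si](C)(C)C(C)(C)C)c(=O)c3ccccc23)nnc1SCCCCCCCC(=O)Nc1ccc(Cl)cc1Cl`, gives the limit > 30000 nM.
Compound 3, `Cn1c(Cc2nn(CCCO)c(=O)c3ccccc23)nnc1SCCCCCCCC(=O)Nc1ccc(Cl)cc1Cl`, gives the limit > 30000 nM.

These three were tested in an assay on 32D cells for inhibition of interleukin-15 (Mus musculus), read by resazurin assay, with stated times of 30 min and 2.5 days, in the presence of a further agent that is not named here; on this read-out lower numbers stand for stronger inhibition and higher numbers for weaker inhibition. Within the data shown here, compound 1 is the only one with a readable number. Compound 2 reaches only the limit of this assay. Compound 3 likewise sits at the limit, so nothing finer than that is known about it. Two steps can still be read in part: an at least 7.6-fold higher number from compound 1 to compound 2 (0.88 log units; beyond the scatter) and an at least 7.6-fold higher number from compound 1 to compound 3 (0.88 log units; beyond the scatter) both show a loss of potency, each given only as a lower bound because both end at the limit of > 30000 nM in this assay, at which 2 of the 3 values shown sit. By contrast a step that the two limits leave unreadable from compound 2 to compound 3 cannot be read at all.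

Compound 4, `Cn1c(Cc2nn(CCC(=O)O)c(=O)c3ccccc23)nnc1SCCCCCCCC(=O)Nc1ccc(Cl)cc1Cl`, differs from compound 3 by carboxy in place of hydroxymethyl on a saturated chain carbon, two bonds along the chain from an aromatic nitrogen. Among the measured compounds shown here, no measured step exchanges an alcohol for an acid, so no direct precedent exists. Both earlier additions on that chain carbon pushed the number past the limit, and compound 3 itself stands at the limit, so compound 4 is expected to stay near it, with an estimated a number no higher from compound 3 to compound 4 (the limit leaves the size open) of unreadable size. Compound 4 is estimated at 30000 nM, within a range from 8000 nM to 100000 nM.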

Compound 4, half-maximal inhibitory concentration: > 30000 nM
Compound 4 gave a limit, no number (the forecaster's own chance of this, stated with the estimate: 65%); the middle value sits exactly at the limit.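

Carboxymethyl in place of hydrogen on a saturated chain carbon bound to an aromatic nitrogen gives an at least 7.6-fold higher number from compound 1 to compound 4 (0.88 log units; beyond the scatter) in this assay, so a chain ending in carboxy shows a loss of potency, as the chain ends of compound 2 and compound 3 did. Exchanging hydroxymethyl for carboxy does not restore a readable number: compound 4 gives > 30000 nM, which is a limit. The steps among compound 2, compound 3 and compound 4 cannot be read, so no order among these three is known, and three different chain ends now share one result: the limit of > 30000 nM in this assay, at which 3 of the 4 values shown sit.

From the compounds shown here alone, it remains open how far beyond the limit these three lie. An ethyl group, or a chain ending in an amine, would help show whether the loss follows the chain itself or the group at its end.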